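A few compounds are considered here, and "the series" means these few. Any claim that something is new, unique, unknown or untested is made for them only; others in the source may bear on it.

Working notes on the series. In a functional assay on MGC-803 cells (Homo sapiens) for antiproliferative activity, read by CCK-8 assay, with a stated time of 72 h, tested at 8 uM (on this read-out higher numbers stand for a stronger effect at the one concentration tested and lower numbers for a weaker effect), compound 2 `Cc1ccc(N2CCN(C(=S)SCc3ccc(C(=O)Nc4ccccc4N)cc3)CC2)cc1` gives 19.8%, the lowest of the three numbers shown. Compound 1 `COc1ccc(N2CCN(C(=S)SCc3ccc(C(=O)Nc4ccccc4N)cc3)CC2)cc1` gives 22.9% in this assay; the step of a number 3.1 percentage points lower from compound 1 to compound 2 (within the scatter) lies within the scatter. Compound 3 `Nc1ccccc1NC(=O)c1ccc(CSC(=S)N(Cc2ccccc2)Cc2ccccc2)cc1` gives 30.7% in this assay, beyond the scatter above compound 2. Compound 4 `Nc1ccccc1NC(=O)c1ccc(CSC(=S)N2CCN(Cc3ccccc3)CC2)cc1` is not yet measured; it differs from compound 2 by benzyl in place of 4-methylphenyl on an amine nitrogen in a ring. Within the data shown here, no measured step exchanges an aryl for a benzyl on the ring nitrogen; the only step at hand, a number 3.1 percentage points lower from compound 1 to compound 2 (within the scatter), concerns a different change and does not bear on it. Among the measured compounds shown here, compound 3, with two benzyl groups on its nitrogen, sits higher than compound 2, but no single step connects them. The step expected is a number 6.2 percentage points higher from compound 2 to compound 4 (within the scatter), with a wide range. Compound 4 is estimated at 26%, between 14% and 38%.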

Compound 4, a percentage reported as inhibition, at one concentration (the size of the read-out at that concentration, not a potency): 19.7%
Estimate against measurement, compound 4: 6.3 percentage points above; measured number inside the range.
By their numbers in this assay, from the lowest: compounds 4, 2, 1 and 3 (each within the scatter of the next, the first and the last beyond it).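

In this assay, among these compounds, benzyl in place of 4-methylphenyl on an amine nitrogen in a ring gives a number 0.1 percentage points lower from compound 2 to compound 4 (within the scatter) and benzyl in place of 4-methoxyphenyl on the same nitrogen gives a number 3.2 percentage points lower from compound 1 to compound 4 (within the scatter) as the first readable exchange of an aryl for a benzyl at this position. Across these two steps, the change of group on this nitrogen does not separate the compounds. Nothing available bears on the reason for this result.

From the compounds shown here alone, whether an amine, a carboxylic acid or a longer chain on this nitrogen would give a step beyond the scatter remains open.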